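A few compounds are considered here, and "the series" means these few. Any claim that something is new, unique, unknown or untested is made for them only; others in the source may bear on it.

Measured compounds:
- compound 1, `C[C@H](c1ccc(F)cc1)N(Cc1cccc(C(=O)O)c1)C(=O)c1cc2ccccn2n1`: 94 nM in an assay on CHO T-rex cells for antagonist activity at transient receptor potential cation channel subfamily M member 8 (Homo sapiens), read by calcium flux, with a stated time of 20 min; on this read-out lower numbers stand for stronger inhibition and higher numbers for weaker inhibition
- compound 2, `C[C@H](c1ccc(F)cc1)N(Cc1cccc(C(=O)O)c1)C(=O)c1cc2ccccc2cn1`: 90 nM

Of the compounds shown here, two have been measured so far, and they share a common core bearing a carboxylic acid-substituted benzyl group and a 1-(4-fluorophenyl)ethyl group on the same nitrogen. In this assay compound 1 gives 94 nM, the higher of the two numbers, and compound 2 gives 90 nM. Going by the values given here, the only step between them is a 1.0-fold lower number from compound 1 to compound 2 (0.02 log units; within the scatter), so on these numbers the two compounds cannot be told apart.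

Compound 3, `C[C@H](c1ccc(F)cc1F)N(Cc1cccc(C(=O)O)c1)C(=O)c1cc2ccccn2n1`, has not yet been measured. It differs from compound 1 by fluoro in place of hydrogen on an aromatic carbon. Among the compounds with values here, no measured step touches this ring; the single step from compound 1 to compound 2 changes the group on the carbonyl carbon and so gives no direct guidance. With nothing pointing either way, the expectation is a step of a 1.0-fold lower number from compound 1 to compound 3 (0.02 log units; within the scatter), none beyond the scatter. Compound 3 is therefore estimated at 90 nM, with a range from 35 nM to 230 nM.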

Compound 3, half-maximal inhibitory concentration in the transient receptor potential cation channel subfamily M member 8 assay: 234 nM
The estimate for compound 3 lay 2.6-fold (0.41 log units) below the measured number; the measured number lies above the stated range.
By their numbers in the transient receptor potential cation channel subfamily M member 8 assay, from the lowest: compounds 2 and 1 (each within the scatter of the next); then compound 3.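

In the transient receptor potential cation channel subfamily M member 8 assay compound 1 gives 94 nM and compound 3 gives 234 nM with fluoro in place of hydrogen on an aromatic carbon ortho to a large group, which turns the 1-(4-fluorophenyl)ethyl into the 1-(2,4-difluorophenyl)ethyl, giving a 2.5-fold higher number from compound 1 to compound 3 (0.40 log units; beyond the scatter) and so pointing to weaker inhibition. Going by these compounds alone, this is the first step in the set that lies beyond the scatter, and it shows that a single added heavy atom on this ring is enough to move the number, whereas the larger exchange on the carbonyl carbon left it within the scatter. In a physicochemical assay for lipophilicity (a lower number here means a more polar compound, a higher number a more lipophilic compound), compound 1 gives 0.9 and compound 3 gives 0.9 so the same exchange shows no change at the digits printed from compound 1 to compound 3 (within the scatter) and nothing measured here explains why inhibition weakens at this position.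

The compounds shown leave open whether a chloro or a methyl on this same aromatic carbon would raise the number as well, and whether a fluoro on a different carbon of this ring would do the same. Within the data shown here, it also remains open whether the added fluoro has a similar effect when the group on the carbonyl carbon is the one in compound 2, as this step has been read on the core of compound 1 alone.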